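A few compounds are considered here, and "the series" means these few. Any claim that something is new, unique, unknown or untested is made for them only; others in the source may bear on it.

Measured compounds:
- Compound 1 `Fc1ccc(-c2ncnc3c2cnn3CCN2CCCCC2)cc1` gives 95 nM in an assay on HEK293 cells for displacement of a labelled ligand from Sigma non-opioid intracellular receptor 1 (Homo sapiens), read by scintillation counting, with a stated time of 120 min; on this read-out higher numbers stand for weaker inhibition and lower numbers for stronger inhibition.
- Compound 2 `Cn1nccc1-c1ncnc2c1cnn2CCN1CCCCC1` gives 41 nM in this assay.

Among the measured compounds shown here, compound 2 holds the lowest of the two numbers in this assay; the only measured step, a 2.3-fold lower number from compound 1 to compound 2 (0.36 log units; beyond the scatter), puts 1-methyl-1H-pyrazol-5-yl in place of 4-fluorophenyl on an aromatic carbon of the shared core. Compound 3 `Cn1cnc(-c2ncnc3c2cnn3CCN2CCCCC2)c1` differs from compound 2 by 1-methyl-1H-imidazol-4-yl in place of 1-methyl-1H-pyrazol-5-yl on an aromatic carbon. For the measured compounds named here, no measured step covers this exchange of one five-membered aromatic ring for another at the same aromatic carbon. Going by the values given here, the one step that bears on it at all, the swap of the whole aromatic group from compound 1 to compound 2, was modest, and the two five-membered rings in question match in every counted feature. Compound 3 is therefore expected to show no step beyond the scatter, a 1.2-fold higher number from compound 2 to compound 3 (0.09 log units; within the scatter). Compound 3 is estimated at 50 nM, within a range from 15 nM to 160 nM.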

Compound 3, inhibition constant: 11800 nM
Estimate against measurement, compound 3: 240-fold (2.37 log units) below; the whole stated range lies below it.
By their numbers in this assay, from the lowest: compound 2; then compound 1; then compound 3.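

In this assay, among the compounds shown here, this aromatic carbon of the shared core proves far more demanding than the earlier compounds could show: the two groups have the same atoms and match in every counted feature, yet 1-methyl-1H-imidazol-4-yl in place of 1-methyl-1H-pyrazol-5-yl gives a 290-fold higher number from compound 2 to compound 3 (2.46 log units; beyond the scatter) and marks the change as large. Against 4-fluorophenyl the same group gives a 120-fold higher number from compound 1 to compound 3 (2.09 log units; beyond the scatter) while the pyrazole gave only the modest 2.3-fold lower number from compound 1 to compound 2 (0.36 log units; beyond the scatter) in the opposite direction, so a five-membered aromatic ring with two hetero atoms does not by itself decide the outcome here. Nothing at hand accounts for the gap between the two rings.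

The compounds shown leave open how other arrangements of the same atoms, such as 1-methyl-1H-imidazol-5-yl or 1-methyl-1H-pyrazol-4-yl, would read at this carbon. They also leave open how a pyridine ring would read there.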